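Three Analogues Beyond the Limit, and a Chlorinated Newcomer

The compounds below may be only part of what the source reports. "The series", "measured", "known", "first", "only" and "open" are said of these compounds alone.

Compound 1 `Cc1cccc(-n2nncc2CN2C(=O)C3(C(C#N)=C(N)Oc4c3c3nc5ccccc5nc3c3ccccc43)c3ccccc32)c1`: > 50000 nM
Compound 2 `N#CC1=C(N)Oc2c(c3nc4ccccc4nc3c3ccccc23)C12C(=O)N(Cc1cnnn1-c1ccc(N)cc1)c1ccccc12`: > 50000 nM
Compound 3 `N#CC1=C(N)Oc2c(c3nc4ccccc4nc3c3ccccc23)C12C(=O)N(Cc1cnnn1-c1ccc(S(N)(=O)=O)cc1)c1ccccc12`: > 50000 nM

All three compounds were tested in a functional assay on MCF7 cells (Homo sapiens) for antiproliferative activity, read by MTT assay, with a stated time of 48 h; a higher number here means a weaker inhibitor, a lower number a stronger inhibitor. Compound 1 gives only a limit in this assay, so no number for its potency is known. Compound 2 likewise reaches only a limit. Compound 3 also sits at a limit. The three share the same core and differ only in the aryl group on the aromatic nitrogen of the triazole ring. The step that the two limits leave unreadable from compound 1 to compound 2 and the step that the two limits leave unreadable from compound 1 to compound 3 cannot be sized, and the same holds for a step that the two limits leave unreadable from compound 2 to compound 3, because of the limit of > 50000 nM in this assay, at which 3 of the 3 values shown sit.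

Compound 4 `Cc1ccc(Cl)cc1-n1nncc1CN1C(=O)C2(C(C#N)=C(N)Oc3c2c2nc4ccccc4nc2c2ccccc32)c2ccccc21` is the new member. Relative to compound 1 the change is 5-chloro-2-methylphenyl in place of 3-methylphenyl on an aromatic nitrogen. Within the data shown here, every step that could bear on this change is unreadable, and nothing among the measured compounds suggests that any aryl group on this nitrogen brings the value below the limit. The expectation is therefore that the step that the limit leaves unreadable from compound 1 to compound 4 will again be one that the assay cannot resolve. Compound 4 is estimated at 70000 nM, with a range from 25000 nM to 250000 nM, and most likely only a limit will be reported.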

Compound 4, half-maximal inhibitory concentration: > 50000 nM
Compound 4 gave a limit, no number; the forecaster's own chance of this, stated with the estimate: 85%; the middle value is on the limit's open side.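

In this assay compound 4 gives > 50000 nM which is a limit and not a number. No step between compound 4 and compound 1, compound 2 or compound 3 can be read, because all four compounds stop at the same limit: the limit of > 50000 nM in this assay, at which 4 of the 4 values shown sit.

What the compounds shown leave open is how strongly any of the four acts on these cells, and whether any aryl group on this nitrogen would bring a value under the limit.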